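The compounds below may be only part of what the source reports. "The series", "measured", "known", "first", "only" and "open" are said of these compounds alone.

Compound 1 `CC(C)c1ccc(NC(=O)N2CCN(c3ncccc3Cl)CC2)cc1` gives the lower of the two numbers recorded so far in a functional assay on HEK293 cells for antagonist activity at transient receptor potential cation channel subfamily V member 1 (Rattus norvegicus) (a higher number here means a weaker inhibitor, a lower number a stronger inhibitor), at 17.3 nM. Within the data shown here, its only measured neighbour, compound 2 `CCc1cccnc1N1CCN(C(=O)Nc2ccc(C(C)C)cc2)CC1`, gives in this assay 828 nM; the step of a 48-fold higher number from compound 1 to compound 2 (1.68 log units; beyond the scatter) is the single measured step in the set, and it exchanges ethyl for chloro on an aromatic carbon in another part of the shared core.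

Compound 3 `CCCCc1ccc(NC(=O)N2CCN(c3ncccc3Cl)CC2)cc1` differs from compound 1 as butyl in place of isopropyl on an aromatic carbon. Among the measured compounds shown here, no measured step varies this alkyl group para to the large group, so the measured step from compound 1 to compound 2 does not bear directly on the change; it only shows that the scaffold tolerates little alteration in one other place. For the measured compounds named here, with no direct precedent, the change from compound 1 to compound 3 is expected to give a small step, a 1.4-fold higher number from compound 1 to compound 3 (0.16 log units; within the scatter), within or near the scatter. Compound 3 is therefore estimated at 25 nM, with a range from 8 nM to 80 nM.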

Compound 3, half-maximal inhibitory concentration: 203 nM
The estimate for compound 3 lay 8.1-fold (0.91 log units) below the measured number, and the stated range ends below it.
By their numbers in this assay, from the lowest: compound 1; then compound 3; then compound 2.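

In this assay the alkyl group on the aromatic carbon para to a large group proves to be a sensitive place: butyl in place of isopropyl gives a 12-fold higher number from compound 1 to compound 3 (1.07 log units; beyond the scatter) and makes this a second place in the shared core where one alkyl change moves the number beyond the scatter. The change adds one carbon and alters no count of rings, hydrogen-bond donors or acceptors, and no net charge, so a large step does not require a change in any of these. No measurement available here accounts for the loss.

As far as these compounds go, whether the step follows chain length or the loss of branching stays open, and propyl and tert-butyl at this place would separate the two. A methoxy group or an amine here would show whether anything other than an alkyl group is accepted.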